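Pyridin-4-yl exchanged for a methylsulfonyl pyrazole

The compounds below may be only part of what the source reports. "The series", "measured", "known", "first", "only" and "open" are said of these compounds alone.

Compound 2 `CNC(=O)N1CCCc2ccc(NC(=O)c3ccc(-c4ccncc4)cc3)cc21` was tested in a functional assay on MV4-11 cells (Homo sapiens) for antiproliferative activity, with a stated time of 6 days, tested at 6.25 uM (a higher number here means a stronger effect of the compound at the concentration tested, a lower number a weaker effect), and gives 88.7%. Compound 1 `CNC(=O)N1CCCc2ccc(NC(=O)c3ccc(-c4cnn(C)c4)cc3)cc21` gives 94.4% in this assay, so the two numbers lie within the scatter of each other, the change being a number 5.7 percentage points lower from compound 1 to compound 2 (within the scatter). Compound 3 `CNC(=O)N1CCCc2ccc(NC(=O)c3ccc(-c4cnn(S(C)(=O)=O)c4)cc3)cc21` differs from compound 2 by 1-(methylsulfonyl)-1H-pyrazol-4-yl in place of pyridin-4-yl on an aromatic carbon. For the measured compounds named here, the only measured step that bears on this exchange of the ring at the same place stayed within the scatter, so a step of a number 1.3 percentage points higher from compound 2 to compound 3 (within the scatter) is expected, not beyond the scatter. Compound 3 is therefore estimated at 90%, with a range from 78% to 98%.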

Compound 3, a percentage reported as inhibition, at one concentration (the size of the read-out at that concentration, not a potency): 40.2%
Beside the measured number, compound 3's estimate is 49.8 percentage points above it; the whole stated range lies above it.
By their numbers in this assay, from the lowest: compound 3; then compounds 2 and 1 (each within the scatter of the next).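

In this assay, the exchange of pyridin-4-yl for 1-(methylsulfonyl)-1H-pyrazol-4-yl gives a number 48.5 percentage points lower from compound 2 to compound 3 (beyond the scatter), so this position is not indifferent to every ring it carries, as the earlier pair alone might have suggested. With the pyrazole kept, methylsulfonyl in place of methyl on the aromatic nitrogen gives a number 54.2 percentage points lower from compound 1 to compound 3 (beyond the scatter), which places the loss on that one group rather than on the ring. Nothing available explains this loss. Going by these compounds, whether an acetyl group or a longer chain such as propyl on that nitrogen would bring a similar loss stays open.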